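A few compounds are considered here, and "the series" means these few. Any claim that something is new, unique, unknown or untested is made for them only; others in the source may bear on it.

Notes on the series: in a functional assay on HepG2 cells (Homo sapiens) for antiproliferative activity, read by MTT assay, with a stated time of 48 h (on this read-out lower numbers stand for stronger inhibition and higher numbers for weaker inhibition), compound 1 (`Cc1ccc(Oc2nc3ccccc3cc2/C=N/NC(=O)Cn2c([N+](=O)[O-])cnc2C)cc1`) gives 27100 nM and compound 2 (`Cc1ccc2nc(Oc3ccccc3)c(/C=N/NC(=O)Cn3c([N+](=O)[O-])cnc3C)cc2c1`) gives 15100 nM. These two values lie within the usual scatter of each other, so compound 2 shares its standing with compound 1 and neither can be ranked ahead. Among the measured compounds shown here, both sit in the same range of weak values, and no measured compound stands apart from the other.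

Next in the series is compound 3 (`Cc1ccc(Oc2nc3ccc(C)cc3cc2/C=N/NC(=O)Cn2c([N+](=O)[O-])cnc2C)cc1`), which differs from compound 2 by methyl in place of hydrogen on an aromatic carbon. Cut one bond further out, the same difference reads phenoxy to 4-methylphenoxy.

For the measured compounds named here, no pair of measured compounds differing in one place is available, so the size of this change in this assay has no direct measured precedent. Going by the values given here, the only guide is the narrow spread between the two values already in hand. On that basis, the expected 1.1-fold higher number from compound 2 to compound 3 (0.05 log units; within the scatter) does not go beyond the scatter, and no clear direction is expected.

For compound 3 the estimated value is 17000 nM, with an expected range of 7000 nM to 40000 nM.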

Compound 3, half-maximal inhibitory concentration: 21900 nM
Compound 3: middle estimate off by 1.3-fold (0.11 log units), on the low side; low and high end bracket the measured number.
By their numbers in this assay, from the lowest: compounds 2, 3 and 1 (each within the scatter of the next).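

In this assay the series now has its first measured pairs differing in one place, and both are the same kind of change, methyl in place of hydrogen on an aromatic carbon. Where phenoxy becomes 4-methylphenoxy on the compound 2 scaffold, the step is small (a 1.5-fold higher number from compound 2 to compound 3 (0.16 log units; within the scatter)), and where the methyl group enters the core of compound 1 instead, it is equally unresolved (a 1.2-fold lower number from compound 1 to compound 3 (0.09 log units; within the scatter)), so neither place shows a response to this methyl group that can be told from the scatter. No measurement that could explain this result is available.

The compounds shown carry only hydrogen or methyl at these two places, so it remains open whether another group there, such as a methoxy group, a chlorine atom or an amine, would move the number beyond the scatter. Also open, as far as these compounds go, is whether any change elsewhere, for instance to the side chain bearing the nitro group, would separate a compound from the three whose values so far cannot be ranked against one another.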